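The source may hold more compounds than are shown below. What is called first, only, known or untested is meant among the compounds shown, and "the series" means these compounds.

Measured so far:
Compound 1, `O=C(NCc1ccc(OCc2ccccc2)cc1)n1cccn1`: 900 nM
Compound 2, `Cc1cnn(C(=O)NCc2ccc(OC(c3ccccc3)c3ccccc3)cc2)c1`: > 100000 nM

In an assay on membranes from brain for binding affinity to Monoglyceride lipase (Mus musculus), read by fluorescence, with stated times of 1 h and 30 min (a lower number here means a stronger inhibitor, a higher number a weaker inhibitor), compound 1 gives 900 nM. For compound 2 only a limit of the assay is known, > 100000 nM, so compound 2 stands at the far weak end of what this assay reports, at the limit of > 100000 nM in this assay, at which 1 of the 2 values shown sits. Going by the values given here, compound 2 and compound 1 differ in more than one place, so their two values show only that one is a number and the other a limit.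

Compound 3, `O=C(NCc1ccc(OC(c2ccccc2)c2ccccc2)cc1)n1cccn1`, is not yet measured. It differs from compound 2 in a single change, (hydrogen in place of methyl on an aromatic carbon), hydrogen in place of methyl on an aromatic carbon; the rest of the structure is kept. Among the compounds with values here, with no comparable pair measured, the size of this step is open. Since compound 2 sits at a limit, the step from compound 2 to compound 3 in this assay is expected to go toward stronger binding, though by how much cannot be read from the data, and the estimate for compound 3 is 8000 nM, within 800 nM to 100000 nM, meaning an expected step of an at least 12-fold lower number from compound 2 to compound 3 (1.09 log units; beyond the scatter).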

Compound 3, half-maximal inhibitory concentration: > 100000 nM
Compound 3: a limit, no number; the forecaster's own chance of this, stated with the estimate: 30%; middle value at least 12-fold (1.09 log units) from the limit.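

With 1H-pyrazol-1-yl in place of 4-methyl-1H-pyrazol-1-yl, compound 3 also gives only a limit, so the step from compound 2 cannot be read and any effect of the methyl stays hidden. In this assay, going by these compounds alone, the single change from compound 1, phenyl in place of hydrogen on a saturated chain carbon bound to an aromatic carbon and an oxygen on an aromatic ring, is an at least 110-fold higher number from compound 1 to compound 3 (2.04 log units; beyond the scatter) and is the first readable step here. That one phenyl is enough to carry the core of compound 1 to the end of the range: the limit of > 100000 nM in this assay, at which 2 of the 3 values shown sit.

On these data alone, how far past the limit compound 2 and compound 3 lie remains open, as does what the methyl would do on the core of compound 1, where a number could show it. Also open, as far as these compounds go, is how a smaller group on that chain carbon, such as a methyl or a hydroxyl, would read.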